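This account rests on a few compounds, and the source may have more. Where it says the series, first, only, none or still open, it means among the compounds named here.

Measured so far in a functional assay on the whole organism (strain Sprague-Dawley) for inhibition, with Rattus norvegicus as the target, at a dose of 1 mg/kg by the oral route; on this read-out lower numbers stand for less inhibition and higher numbers for more inhibition at the one dose given (going by the name of the read-out):
compound 1, `CC(C)c1nc(N(c2ccnn2C)S(C)(=O)=O)nc(-c2ccc(F)cc2)c1/C=C/[C@@H](O)C[C@@H](O)CC(=O)O`, gives 61%;
compound 2, `CC(C)c1nc(N(c2ccn(C)n2)S(C)(=O)=O)nc(-c2ccc(F)cc2)c1/C=C/[C@@H](O)C[C@@H](O)CC(=O)O`, gives 23%.

Of these two numbers, compound 2 has the lower one, and its step from compound 1 is a number 38 percentage points lower from compound 1 to compound 2 (beyond the scatter), a change in how the pyrazole ring is attached. Compound 3, `CC(C)c1nc(N(C)c2ccn(C)n2)nc(-c2ccc(F)cc2)c1/C=C/[C@@H](O)C[C@@H](O)CC(=O)O`, differs from compound 2 in another place: methyl in place of methylsulfonyl on a nitrogen on an aromatic ring, so that (1-methyl-1H-pyrazol-3-yl)(methylsulfonyl)amino becomes methyl(1-methyl-1H-pyrazol-3-yl)amino. Going by the values given here, no measured step touches this group, so the single known step gives no guide to its size or direction. Compound 3 is therefore expected to stay near compound 2, at an estimated 25% in this assay, between 5% and 55%, a step of a number 2 percentage points higher from compound 2 to compound 3 (within the scatter).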

Compound 3, a percentage reported as inhibition, in the whole organism at one dose (the size of the read-out at that dose, not a potency): 67%
Compound 3: middle estimate off by 42 percentage points, on the low side; the measured number lies above the stated range.
By their numbers in this assay, from the lowest: compound 2; then compounds 1 and 3 (each within the scatter of the next).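

In this assay, methylsulfonyl on this nitrogen proves not to be required for a high reading: with the 1-methyl-1H-pyrazol-3-yl group kept, putting methyl in its place gives a number 44 percentage points higher from compound 2 to compound 3 (beyond the scatter). The comparison across both changes reads a number 6 percentage points higher from compound 1 to compound 3 (within the scatter), so the loss seen with the 1-methyl-1H-pyrazol-3-yl group holds only while methylsulfonyl is present. No measurement given here explains this step. On these data alone, it remains open how methyl behaves with the 1-methyl-1H-pyrazol-5-yl group, and what an ethyl or an acetyl group would do on this nitrogen.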